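Shortening the carbamate-bearing chain: compound 2 to compound 4

The compounds below may be only part of what the source reports. "The series", "measured", "known", "first", "only" and "open" are said of these compounds alone.

Measured compounds:
- compound 1 `CC(C)(C)OC(=O)NCCCCNC(=O)CN1CN(c2ccccc2)C2(CCN(C(=O)c3ccc(C(C)(C)C)cc3)CC2)C1=O`: "not determined" (no result reported) in an assay on HEK293 cells for displacement of a labelled ligand from NPC1-like intracellular cholesterol transporter 1 (Homo sapiens); a higher number here means a weaker inhibitor, a lower number a stronger inhibitor
- compound 2 `CC(C)(C)OC(=O)NCCCNC(=O)CN1CN(c2ccccc2)C2(CCN(C(=O)c3ccc(C4CCCCC4)cc3)CC2)C1=O`: 6000 nM
- compound 3 `CC(C)(C)OC(=O)NCCCNC(=O)CN1CN(c2ccccc2)C2(CCN(C(=O)c3ccc(C(C)(C)C)cc3)CC2)C1=O`: 4500 nM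

Compound 2 stands at the highest of the two numbers in this assay. Its nearest neighbour is compound 3, and the change a 1.3-fold lower number from compound 2 to compound 3 (0.12 log units; within the scatter) lies within the scatter, so the two are not separated. Compound 1 carries one more chain carbon than compound 3 and has no number, so it gives nothing to compare with.

The next compound, compound 4 `CC(C)(C)OC(=O)NCCNC(=O)CN1CN(c2ccccc2)C2(CCN(C(=O)c3ccc(C4CCCCC4)cc3)CC2)C1=O`, differs from compound 2 by (tert-butoxycarbonyl)amino in place of ((tert-butoxycarbonyl)amino)methyl on a saturated chain carbon, two bonds along the chain from an amide-type nitrogen. Going by the values given here, the only measured step, from compound 2 to compound 3, concerns the substituent on the aromatic carbon, not the chain, and it was within the scatter. Among the compounds with values here, no measured pair speaks to a change of chain length, so there is nothing in the numbers that points to a step in either direction.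

For compound 4 the expectation is therefore a value close to that of compound 2, an estimated 6000 nM with a range from 2500 nM to 15000 nM. Within the data shown here, the step of no change at the digits printed from compound 2 to compound 4 (within the scatter) is expected to stay within the scatter, with the range kept wide because no measured step covers this kind of change.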

Compound 4, half-maximal inhibitory concentration: 5500 nM
For compound 4 the middle estimate is 1.1-fold (0.04 log units) above the measured one, and the stated range covers the measured number.
By their numbers in this assay, from the lowest: compounds 3, 4 and 2 (each within the scatter of the next).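

Shortening the chain, with (tert-butoxycarbonyl)amino in place of ((tert-butoxycarbonyl)amino)methyl on a saturated chain carbon, gives the first pair with numbers on both sides for a change of chain length in this assay: a 1.1-fold lower number from compound 2 to compound 4 (0.04 log units; within the scatter), so the two compounds are not separated. With cyclohexyl held constant on the aromatic carbon, the 3-((tert-butoxycarbonyl)amino)propyl and 2-((tert-butoxycarbonyl)amino)ethyl forms of the chain therefore read alike, a finding that rests on this single pair and does not extend to the tert-butyl compounds. No measured information is available that would explain this result.

Still open is whether an amine or a carboxylic acid in place of the (tert-butoxycarbonyl)amino group would produce a step beyond the scatter in this assay, as the compounds shown all retain that group. Also open, as far as these compounds go, is whether a longer chain, or a shorter one than 2-((tert-butoxycarbonyl)amino)ethyl, would leave the number similarly unchanged, with either cyclohexyl or tert-butyl on the aromatic carbon.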